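The source may hold more compounds than are shown below. What is called first, only, known or untested is meant among the compounds shown, and "the series" means these compounds.

In an ADME assay on WI-38 cells (Homo sapiens) for cytotoxicity, read by MTT assay, with a stated time of 72 h (a lower number here means a stronger inhibitor, a higher number a weaker inhibitor), three compounds sharing one core have been measured. Compound 1 `O=C(CCc1cccc2c1B(O)OC2)NC1CCCCC1`, with cyclohexyl on the amide-type nitrogen, returns only a limit, > 100000 nM. Compound 3 `O=C(CCc1cccc2c1B(O)OC2)Nc1nccs1`, with 1,3-thiazol-2-yl there, also returns only a limit, > 100000 nM. Compound 3 thus stands at the limit of > 100000 nM in this assay, at which 2 of the 3 values shown sit, so no exact number is known for it. Compound 2 `O=C(CCc1cccc2c1B(O)OC2)Nc1ccccc1`, with phenyl on that nitrogen, alone gives a number, 30000 nM.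

Compound 4 `O=C(CCc1cccc2c1B(O)OC2)Nc1ccc(F)cc1` puts 4-fluorophenyl in place of 1,3-thiazol-2-yl on that same nitrogen, a change counted as 4-fluorophenyl in place of 1,3-thiazol-2-yl on an amide-type nitrogen. Among the measured compounds shown here, two measured steps bear on it, and both turn on phenyl: an at least 3.3-fold lower number from compound 1 to compound 2 (0.52 log units; beyond the scatter) and an at least 3.3-fold higher number from compound 2 to compound 3 (0.52 log units; beyond the scatter). Both are beyond the scatter and only modest at the least. A six-membered aromatic ring of carbon only therefore returns here, and a lower number of similar size is expected in this assay. The expected change is an at least 3.3-fold lower number from compound 3 to compound 4 (0.52 log units; beyond the scatter). Compound 4 is estimated at 30000 nM, with an expected range of 12000 nM to 80000 nM.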

Compound 4, half-maximal inhibitory concentration: 12000 nM
Beside the measured number, compound 4's estimate is 2.5-fold (0.40 log units) above it; the range from low to high includes it.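

Compound 4 shows that the amide-type nitrogen's substituent responds to more than the choice of ring: fluoro in place of hydrogen on an aromatic carbon gives a 2.5-fold lower number from compound 2 to compound 4 (0.40 log units; beyond the scatter) in this assay. With 4-fluorophenyl, the contrast with the other two groups also widens, to an at least 8.3-fold lower number from compound 3 to compound 4 (0.92 log units; beyond the scatter) and an at least 8.3-fold lower number from compound 1 to compound 4 (0.92 log units; beyond the scatter). These two steps give only a minimum size because compound 3 and compound 1 both stand at the assay's limit: the limit of > 100000 nM in this assay, at which 2 of the 4 values shown sit.

On these data alone, whether chloro or methoxy in place of the fluoro would lower the number further, or would reverse the step, remains open. So does the effect of an amine or a carboxylic acid on the phenyl ring, since fluoro is the only substituent on that ring among these compounds.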